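Swapping chloro for methoxy on the outer phenyl ring

The source may report more compounds than this note shows. Statements on the series, on what has been measured and on what is new or still open speak of the compounds shown alone.

Within the data shown here, compound 2 `O=C(/C=C\Nc1ccc(O)cc1)c1cn(-c2ccccc2)nc1-c1ccc(Cl)cc1` is the only compound here with a numerical result: in an ADME assay on HaCaT cells (Homo sapiens) for antiproliferative activity, read by MTT assay, with a stated time of 48 h (on this read-out higher numbers stand for weaker inhibition and lower numbers for stronger inhibition), compound 2 gives 22600 nM. Compound 1 `O=C(/C=C\Nc1ccc(C(F)(F)F)cc1)c1cn(-c2ccccc2)nc1-c1ccc(Cl)cc1` reaches only a limit, > 50000 nM, in this assay. The change from trifluoromethyl to hydroxy brought an at least 2.2-fold lower number from compound 1 to compound 2 (0.34 log units; beyond the scatter). Compound 3 `COc1ccc(-c2nn(-c3ccccc3)cc2C(=O)/C=C\Nc2ccc(O)cc2)cc1` differs from compound 2 by methoxy in place of chloro on an aromatic carbon. Among the measured compounds shown here, no measured step touches a change of this kind, so no shift beyond the scatter is expected. Compound 3 is therefore estimated at 25000 nM, between 8000 nM and 80000 nM. That estimate amounts to an expected 1.1-fold higher number from compound 2 to compound 3 (0.04 log units; within the scatter).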

Compound 3, half-maximal inhibitory concentration: 34600 nM
Beside the measured number, compound 3's estimate is 1.4-fold (0.14 log units) below it, and the stated range covers the measured number.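

Going from 4-chlorophenyl to 4-methoxyphenyl gives a 1.5-fold higher number from compound 2 to compound 3 (0.18 log units; within the scatter), so in this assay this swap on the aromatic carbon does not move the result past ordinary variation. Among these compounds, the earlier step changed a different place, which makes this the first reading at this position, and it rests on a single pair. Nothing shown here offers a reason for this result. Going by these compounds, whether an amine, a carboxylic acid or a longer chain such as butoxy at this position would shift the number beyond the scatter remains open.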